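Hydrogen in Place of Fluoro on Compound 1

The source may hold more compounds than are shown below. What is called first, only, known or untested is meant among the compounds shown, and "the series" means these compounds.

Going by the values given here, in an assay on cells for inhibition of HSP60/HSP10 (Homo sapiens), with a stated time of 60 min (a higher number here means a weaker inhibitor, a lower number a stronger inhibitor), compound 1 `O=S(=O)(Nc1ccc(-c2nc3ccccc3o2)cc1)c1ccc(F)c(C(F)(F)F)c1` gives 28000 nM, the lowest of the three numbers measured so far. Compound 2 `O=S(=O)(Nc1ccc(-c2nc3ccccc3o2)cc1)c1ccc(Cl)s1` gives 31000 nM, a number within the usual scatter of that of compound 1, so the two cannot be ranked against each other. Compound 3 `O=S(=O)(Nc1ccc(-c2nc3cc(NS(=O)(=O)c4ccccc4F)ccc3o2)cc1)c1ccccc1F` gives 57000 nM, which lies beyond the scatter above the number for compound 1. Compound 4 `O=S(=O)(Nc1ccc(-c2nc3ccccc3o2)cc1)c1cccc(C(F)(F)F)c1` has not yet been measured. Its difference from compound 1 is hydrogen in place of fluoro on an aromatic carbon. Among the compounds with values here, no pair of measured compounds shows a change of this kind, so the data give no direct guide. The change is small, and the expected step of a 1.1-fold higher number from compound 1 to compound 4 (0.03 log units; within the scatter) is none beyond the scatter. Compound 4 is therefore estimated at 30000 nM, with a range from 12000 nM to 75000 nM.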

Compound 4, half-maximal inhibitory concentration: 57000 nM
Estimate against measurement, compound 4: 1.9-fold (0.28 log units) below, and the stated range covers the measured number.
By their numbers in this assay, from the lowest: compounds 1, 2, 3 and 4 (each within the scatter of the next, the first and the last beyond it).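

Going by these compounds alone, this is the first single-place change, and in this assay hydrogen in place of fluoro gives a 2.0-fold higher number from compound 1 to compound 4 (0.31 log units; beyond the scatter), a modest step. The position, ortho to a trifluoromethyl group and para to a large group, therefore responds to this change, and the fluoro group goes with the lower number. No measurement on these compounds accounts for the step.

The compounds shown leave open how a methoxy group or an amine at this position would compare with fluoro. They also leave open whether the step would recur without the trifluoromethyl group.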